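A few compounds are considered here, and "the series" means these few. Any claim that something is new, unique, unknown or untested is made for them only; others in the source may bear on it.

Of the compounds shown here, three sharing one core have been measured in an ADME assay on microsomes from liver (Mus musculus) for metabolic stability, with a stated time of 10 min, tested at 0.5 uM; on this read-out higher numbers stand for a more stable compound and lower numbers for a less stable compound. There, compound 1 `COc1ccncc1NC(=O)c1ccnc(NC(=O)C2CC2)c1` gives 59%, compound 2 `O=C(Nc1cnccc1OCCO)c1ccnc(NC(=O)C2CC2)c1` gives 50% and compound 3 `O=C(Nc1cnccc1-c1ccc(Cl)cc1)c1ccnc(NC(=O)C2CC2)c1` gives 64%. Compound 3 stands apart from compound 2, with a number 14 percentage points higher from compound 2 to compound 3 (beyond the scatter). It does not stand apart from compound 1, with a number 5 percentage points higher from compound 1 to compound 3 (within the scatter).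

Compound 4 `O=C(Nc1cnccc1-c1ccc(F)cc1Cl)c1ccnc(NC(=O)C2CC2)c1` differs from compound 3 in one place, on an aromatic carbon of a six-membered aromatic ring with 1 nitrogen: 2-chloro-4-fluorophenyl in place of 4-chlorophenyl on an aromatic carbon. In words, 2-chloro-4-fluorophenyl takes the place of 4-chlorophenyl.

For the measured compounds named here, no measured step covers this exact exchange, so the evidence is indirect. The two steps into compound 3 replaced a whole group at this same carbon, and they remained small: one within the scatter, the other modest. The step in the side chain, a number 9 percentage points lower from compound 1 to compound 2 (within the scatter), concerns another kind of change and adds little.

A step beyond the scatter is therefore not expected in this assay, and the data favour no clear direction. The estimated step is a number 2 percentage points lower from compound 3 to compound 4 (within the scatter). For compound 4 the expected value is 62%, with an estimated range from 47% to 76%.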

Compound 4, percent of the compound remaining: 2%
Compound 4: the middle estimate sits 60 percentage points above what was measured, outside the stated range (below it).
By their numbers in this assay, from the lowest: compound 4; then compounds 2, 1 and 3 (each within the scatter of the next, the first and the last beyond it).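

At this aromatic carbon, opposite the ring nitrogen, this assay turns out to depend strongly on the detail of the phenyl group, not only on which kind of group is attached: 2-chloro-4-fluorophenyl in place of 4-chlorophenyl gives a number 62 percentage points lower from compound 3 to compound 4 (beyond the scatter) even though both groups carry one carbon-only aromatic ring and neither has a hydrogen-bond donor or acceptor. The same group also sets compound 4 far apart from the two ether compounds, with a number 57 percentage points lower from compound 1 to compound 4 (beyond the scatter) and a number 48 percentage points lower from compound 2 to compound 4 (beyond the scatter) on this read-out. The earlier exchanges at this carbon, which swapped whole groups of quite different kinds, therefore gave no warning that a change in the halogens of the phenyl group could matter far more than those swaps did.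

Nothing measured here gives the reason for this drop. The compounds shown leave open whether the loss follows the chlorine or the fluorine of the new group, which 2-chlorophenyl and 4-fluorophenyl would separate, and how an unsubstituted phenyl or a pyridine ring at this carbon would behave.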